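Notes on the amide substituent series: compounds 1 to 4

The compounds below may be only part of what the source reports. "The series", "measured", "known", "first", "only" and "open" are said of these compounds alone.

Measured in a functional assay on HL-60 cells (Homo sapiens), with a stated time of 2 days; on this read-out lower numbers stand for stronger inhibition and higher numbers for weaker inhibition:
compound 1 , `CCCCCCNC(=O)c1[nH]cnc1C(=O)Nc1ccc(Cl)c(Cl)c1`, gives 14600 nM
compound 2 , `COc1ccc(CNC(=O)c2[nH]cnc2C(=O)Nc2ccc(Cl)c(Cl)c2)cc1`, gives 24300 nM
compound 3 , `C[C@H](NC(=O)c1[nH]cnc1C(=O)Nc1ccc(Cl)c(Cl)c1)c1ccccc1`, gives 9200 nM

Compound 1 stands second highest of the three numbers. Its nearest neighbour is a 1.6-fold lower number from compound 1 to compound 3 (0.20 log units; within the scatter); its furthest is a 1.7-fold higher number from compound 1 to compound 2 (0.22 log units; within the scatter). The only gap beyond the scatter in the set is a 2.6-fold lower number from compound 2 to compound 3 (0.42 log units; beyond the scatter), and even that is modest.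

Compound 4 , `COC(=O)[C@@H](C)NC(=O)c1[nH]cnc1C(=O)Nc1ccc(Cl)c(Cl)c1`, is not yet measured. It differs from compound 1 in one place: 1-(methoxycarbonyl)ethyl in place of hexyl on an amide-type nitrogen. All three measured steps alter the group on the same amide-type nitrogen, and all three stay small, so this position has so far tolerated a chain, a 4-methoxybenzyl group and a 1-phenylethyl group without large movement in this assay. Going by the values given here, no measured step brings in an ester or a second oxygen at that position, so the direction for compound 4 cannot be read from the set; the size, on the evidence of the three steps, is expected to stay within or near the scatter.

The expected step is a 1.2-fold higher number from compound 1 to compound 4 (0.09 log units; within the scatter). Compound 4 is therefore estimated at 18000 nM in this assay, with a range from 7000 nM to 45000 nM.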

Compound 4, half-maximal inhibitory concentration: > 62500 nM
Compound 4: no number, only a limit; the forecaster's own chance of this, stated with the estimate: 15%; middle value at least 3.4-fold (0.54 log units) away from the limit.
By their numbers in this assay, from the lowest: compounds 3, 1 and 2 (each within the scatter of the next, the first and the last beyond it). At a limit, above all of these: compound 4.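

In this assay compound 4 alone sits at a limit of the assay and not at a number: the limit of > 62500 nM in this assay, at which 1 of the 4 values shown sits.

All three steps into it lie beyond the scatter: an at least 4.2-fold higher number from compound 1 to compound 4 (0.63 log units; beyond the scatter), an at least 6.7-fold higher number from compound 3 to compound 4 (0.83 log units; beyond the scatter) and an at least 2.5-fold higher number from compound 2 to compound 4 (0.41 log units; beyond the scatter). The amide-type nitrogen therefore does not tolerate every substituent: the hexyl, 4-methoxybenzyl and 1-phenylethyl groups differ by modest steps at most, whereas 1-(methoxycarbonyl)ethyl brings a clear loss, even though it has as many heavy atoms as the hexyl group it replaces and differs in carrying oxygen and hydrogen-bond acceptors.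

As compound 4 gives only a limit, the true size of these steps stays unknown, and the compounds shown do not separate the contribution of the methyl ester from that of its defined stereocentre. Also open, from the compounds shown here alone, is whether the loss persists with a carboxylic acid or a primary amide in place of the methyl ester, or with the ester carried on a longer chain.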